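The source may hold more compounds than are shown below. What is called first, only, known or untested is meant among the compounds shown, and "the series" means these compounds.

Going by the values given here, compound 1 `C=CCC1C(=C)C(=O)N(c2ccccc2)N1c1ccccc1` gives 1320 nM in a functional assay on HL-60 cells (Homo sapiens) for inhibition, read by MTT assay, with a stated time of 48 h (on this read-out higher numbers stand for weaker inhibition and lower numbers for stronger inhibition), and stands as the lowest of the two numbers so far. Compound 2 `C=C1C(=O)N(c2ccccc2)N(C)C1c1ccc(OC)cc1` gives 37300 nM in this assay, a gap from compound 1 that lies beyond the scatter. Compound 3 `C=C1C(=O)N(c2ccccc2)N(c2ccccc2)C1CC` differs from compound 1 by methyl in place of vinyl on a saturated chain carbon bound to a saturated ring carbon. Among the compounds with values here, no measured pair shares this change, so its size is unknown; a small step is expected, at most at the edge of the scatter, in the direction of a higher number. Compound 3 is therefore estimated at 1900 nM in this assay, within 700 nM to 5500 nM. The expected step of a 1.4-fold higher number from compound 1 to compound 3 (0.16 log units; within the scatter) is modest.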

Compound 3, half-maximal inhibitory concentration: 8890 nM
Estimate against measurement, compound 3: 4.7-fold (0.67 log units) below; the measured number lies above the stated range.
By their numbers in this assay, from the lowest: compound 1; then compound 3; then compound 2.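

Changing allyl to ethyl, read as methyl in place of vinyl on a saturated chain carbon bound to a saturated ring carbon, is not a silent change in this assay (a 6.7-fold higher number from compound 1 to compound 3 (0.83 log units; beyond the scatter)). Going by these compounds alone, this is the first single-place comparison, and it shows that the chain at this position affects the read-out, with the lower number belonging to the allyl of compound 1. Nothing available explains this step.

On these data alone, whether a longer chain, a benzyl group or an amine at this place would give a number nearer compound 1 or compound 3 remains open. So does whether the step would persist with other groups elsewhere on the shared core.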